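A few compounds are considered here, and "the series" means these few. Any claim that something is new, unique, unknown or untested is made for them only; others in the source may bear on it.

Measured so far in an assay on cells for inhibition of Rho-associated protein kinase 2 (Homo sapiens), read by radiometric assay and 33P incorporation, in the presence of a further agent that is not named here; on this read-out lower numbers stand for stronger inhibition and higher numbers for weaker inhibition:
compound 1, `NCc1ccc(C(=O)Nc2ccncc2F)cc1-c1cccc(NC(=O)c2cccc(C(=O)O)c2)c1`: compound 1 gives < 1 nM, which is a limit of the assay and not a number.
compound 2, `CCC(C)OC(=O)c1cccc(NC(=O)c2cccc(-c3cc(C(=O)Nc4ccncc4F)ccc3CN)c2)c1`: compound 2 gives 2.6 nM.
compound 3, `NCc1ccc(C(=O)Nc2ccncc2F)cc1-c1cccc(C(=O)Nc2ccccc2)c1`: compound 3 gives < 1 nM, again a limit and not a number.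

Compound 1 therefore stands at the floor of what this assay can report, and it is not alone there: the limit of < 1 nM in this assay, at which 2 of the 3 values shown sit. Because of that, the step that the two limits leave unreadable from compound 1 to compound 3 cannot be read in size. Within the data shown here, the one readable step is an at least 2.6-fold lower number from compound 2 to compound 3 (0.41 log units; beyond the scatter), where a sec-butoxycarbonyl ester on the outer ring gives way to hydrogen and the number falls.

Compound 4, `COC(=O)c1ccc(F)c(C(=O)Nc2cccc(-c3cc(C(=O)Nc4ccncc4F)ccc3CN)c2)c1`, differs from compound 1 as follows: 2-fluoro-5-(methoxycarbonyl)phenyl in place of 3-carboxyphenyl on a carbonyl carbon. Among the measured compounds shown here, no measured step matches this change exactly. The closest comparison is compound 2, which also carries an ester on the outer ring and gives 2.6 nM. Compound 4 is expected to land in a similar region, so the estimate for compound 4 is 2 nM, with a range from 0.7 nM to 6 nM. The expected step is an at least 2.0-fold higher number from compound 1 to compound 4 (0.30 log units; that floor lies within the scatter).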

Compound 4, half-maximal inhibitory concentration: < 1 nM
Compound 4: only a limit was reported; the forecaster's own chance of this, stated with the estimate: 25%; middle value at least 2.0-fold (0.30 log units) from the limit.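

Compound 4 gives < 1 nM as a limit and not a number. Among these compounds, no step from compound 1 to compound 4 can be read, because both compounds stand at the same limit: the limit of < 1 nM in this assay, at which 3 of the 4 values shown sit. From the compounds shown here alone, how far apart the compounds at this limit truly lie stays open.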